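A Halogen Swap on the Saturated Ring Carbon

This account rests on a few compounds, and the source may have more. Where it says the series, first, only, none or still open, it means among the compounds named here.

Compound 1 `CNC(=O)c1cc(Oc2ccc(C3=NNC(c4cccc(Br)c4)C3)cc2)ccn1` is the only compound with a number shown in a functional assay on HepG2 cells (Homo sapiens) for cytotoxicity, read by MTT assay, with a stated time of 72 h; a lower number here means a stronger inhibitor, a higher number a weaker inhibitor; there compound 1 gives 1850 nM. In this assay compound 2 `CNC(=O)c1cc(Oc2ccc(C3=NNC(c4ccc([N+](=O)[O-])cc4)C3)cc2)ccn1` gives only a limit, > 50000 nM. Within the data shown here, the single measured step, an at least 27-fold higher number from compound 1 to compound 2 (1.43 log units; beyond the scatter), is the one that bears on compound 3 `CNC(=O)c1cc(Oc2ccc(C3=NNC(c4ccc(F)cc4)C3)cc2)ccn1`, which differs from compound 1 by 4-fluorophenyl in place of 3-bromophenyl on a saturated ring carbon. Among the measured compounds shown here, that step was large and points toward a higher number, but the entering group differs from the one in compound 2, so a smaller rise is expected: a 2.2-fold higher number from compound 1 to compound 3 (0.33 log units; beyond the scatter). Compound 3 is therefore estimated at 4000 nM, between 1200 nM and 20000 nM.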

Compound 3, half-maximal inhibitory concentration: 5280 nM
Estimate against measurement, compound 3: 1.3-fold (0.12 log units) below; measured number inside the range.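

The exchange of 3-bromophenyl for 4-fluorophenyl raises the number in this assay only modestly, with a 2.9-fold higher number from compound 1 to compound 3 (0.46 log units; beyond the scatter), so this saturated ring carbon can carry a phenyl substituted at a different ring position and keep measurable activity. With the substituent position held, the group itself matters, with an at least 9.4-fold lower number from compound 2 to compound 3 (0.97 log units; beyond the scatter). That step rests on a limit, and compound 2 stands only at that limit: the limit of > 50000 nM in this assay, at which 1 of the 3 values shown sits.

The compounds shown leave open whether the halogen or its ring position drives the rise from compound 1. They also leave open how an amine or a methoxy group on this phenyl would read.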